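The source may report more compounds than this note shows. Statements on the series, on what has been measured and on what is new or still open speak of the compounds shown alone.

Compound 1 `COc1ccc2[nH]c(C(=O)N3CC(=O)N(Cc4ccccc4)[C@@H](CN4CCCC4)C3)cc2c1` is examined in a physicochemical assay for solubility, read by spectrophotometry, in phosphate buffer, with a stated time of 2 h, at pH 7.4; a higher number here means a more soluble compound, a lower number a less soluble compound. In this assay compound 1 reaches only > 25000 nM, which is a limit of the measurement rather than a number, namely (the limit of > 25000 nM in this assay, at which 1 of the 3 values shown sits). Two other compounds give numbers: compound 2 `Cc1ccc2[nH]c(C(=O)N3CC(=O)N(Cc4ccccc4)[C@@H](CN4CCC5(CCC5)CC4)C3)cc2c1` gives 12300 nM, and compound 3 `COc1ccc2[nH]c(C(=O)N3CC(=O)N(Cc4ccc[nH]4)[C@@H](Cc4ccccc4)C3)cc2c1` gives 38400 nM. The account now turns to compound 4 `COc1ccc2[nH]c(C(=O)N3CC(=O)N(Cc4ccccc4)[C@@H](CN4CC5CCCCC5C4)C3)cc2c1`, which differs from compound 1 in one place: a group of 9 heavy atoms (8 carbon, 1 nitrogen; one five-membered non-aromatic ring with 1 hetero atom, one six-membered non-aromatic ring of carbon only) in place of a group of 5 heavy atoms (4 carbon, 1 nitrogen; one five-membered non-aromatic ring with 1 hetero atom), on a saturated chain carbon bound to a saturated ring carbon. Within the data shown here, no measured pair shows this same change, so its size is open. The expectation is a downward step from compound 1 to compound 4 beyond the usual scatter, an at least 3.1-fold lower number from compound 1 to compound 4 (0.49 log units; beyond the scatter). Compound 2, the nearest comparison with its own larger ring group, gives 12300 nM. Compound 4 is therefore estimated at 8000 nM, with a range from 2500 nM to 25000 nM.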

Compound 4, solubility: 23800 nM
Estimate against measurement, compound 4: 3.0-fold (0.47 log units) below; low and high end bracket the measured number.
By their numbers in this assay, from the lowest: compounds 2, 4 and 3 (each within the scatter of the next, the first and the last beyond it).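

At this position on the saturated chain carbon, the group of 9 heavy atoms in place of pyrrolidin-1-yl gives an at least 1.0-fold lower number from compound 1 to compound 4 (0.02 log units; that floor lies within the scatter) in this assay. Going by these compounds, compound 1 stands at a limit and not at a number, so only this floor can be read, and the full size of the step stays unknown: the limit of > 25000 nM in this assay, at which 1 of the 4 values shown sits. A step within the scatter and a larger one both remain possible. The compounds shown leave open how a morpholin-4-yl group or a dimethylamino group would read at this position.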